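The source may report more compounds than this note shows. Statements on the series, on what has been measured and on what is new or still open speak of the compounds shown alone.

Of the compounds shown here, three built on one shared core have been tested in a functional assay on B16-F10 cells (Mus musculus) for inhibition, read by MTT assay, with a stated time of 48 h; a lower number here means a stronger inhibitor, a higher number a weaker inhibitor. Compound 1 `COc1ccc(/C=C/c2cc(OC)cc(OC)c2/C=C/C(=O)Nc2cc(OC)c(OC)c(OC)c2)cc1` gives 8150 nM. Compound 2 `CCCCCCCCNC(=O)/C=C/c1c(/C=C/c2ccc(OC)cc2)cc(OC)cc1OC` gives 8060 nM in this assay, and compound 3 `COc1ccc(/C=C/c2cc(OC)cc(OC)c2/C=C/C(=O)N2CCCC2)cc1` gives 9280 nM. The step of a 1.0-fold lower number from compound 1 to compound 2 (0.00 log units; within the scatter) and the step of a 1.2-fold higher number from compound 2 to compound 3 (0.06 log units; within the scatter) both stay within the scatter. Compound 3 therefore holds the highest of the three numbers, yet its gaps to compound 1 and to compound 2 are each within the scatter, so the three compounds cannot be told apart on these figures.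

Compound 4 `CCNC(=O)/C=C/c1c(/C=C/c2ccc(OC)cc2)cc(OC)cc1OC` has not yet been measured. It differs from compound 3 in one place: ethylamino in place of pyrrolidin-1-yl on a carbonyl carbon. Within the data shown here, two measured steps bear on this change, since each of them also swapped the group sitting on the same carbonyl carbon: a 1.0-fold lower number from compound 1 to compound 2 (0.00 log units; within the scatter) and a 1.2-fold higher number from compound 2 to compound 3 (0.06 log units; within the scatter). Neither swap moved the number beyond the scatter, whether a ring, a long chain or a substituted ring occupied that position. A short chain is expected to behave alike. For compound 4 the expected step is a 1.1-fold lower number from compound 3 to compound 4 (0.04 log units; within the scatter), meaning no change beyond the scatter in either direction. Compound 4 is estimated at 8500 nM, with a range from 4000 nM to 18000 nM.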

Compound 4, half-maximal inhibitory concentration: 6990 nM
Beside the measured number, compound 4's estimate is 1.2-fold (0.08 log units) above it; the range from low to high includes it.
By their numbers in this assay, from the lowest: compounds 4, 2, 1 and 3 (each within the scatter of the next).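

In this assay, replacing the pyrrolidin-1-yl group of compound 3 with ethylamino removes a ring, takes the group from 5 heavy atoms to 3 and adds 1 hydrogen-bond donor, yet the outcome is a 1.3-fold lower number from compound 3 to compound 4 (0.12 log units; within the scatter) and so no real shift can be read from it. The comparisons on the amide nitrogen agree: going from octyl to ethyl gives a 1.2-fold lower number from compound 2 to compound 4 (0.06 log units; within the scatter) while going from 3,4,5-trimethoxyphenyl to ethyl gives a 1.2-fold lower number from compound 1 to compound 4 (0.07 log units; within the scatter) and thus a short chain, a long chain, a substituted ring and a pyrrolidine ring cannot be told apart at this carbonyl carbon. No measurement offers a reason for this insensitivity.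

From the compounds shown here alone, all four compounds keep the same core and carry an uncharged group at this position, so it remains open whether a side chain ending in a basic amine or a carboxylic acid would move the number beyond the scatter. Going by these compounds, the effect of changing the methoxy groups on the core also remains open, since these stay the same throughout the four compounds.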